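The source may hold more compounds than are shown below. What is called first, only, known or untested is meant among the compounds shown, and "the series" means these compounds.

Two esters of a shared core have been measured in a functional assay on K562 cells (Homo sapiens) for cytotoxicity, read by MTT assay; a higher number here means a weaker inhibitor, a lower number a stronger inhibitor. Compound 1 `COc1cc(C(=O)O[C@@H]2C/C=C(\C)CCCC(C)(C)[C@@H](OC(C)=O)/C=C\2C)ccc1O` gives 41500 nM in this assay. Compound 2 `C/C1=C/[C@H](O)C(C)(C)CCC/C(C)=C/C[C@H]1OC(=O)c1ccc(O)cc1` gives > 50000 nM in this assay; this is a limit of the measurement, not a number, which places compound 2 at the limit of > 50000 nM in this assay, at which 1 of the 2 values shown sits. Compound 2 therefore stands at the weak end of what this assay can report, and it can only be compared with compound 1 as a limit beside a number.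

Compound 3 `COc1cc(C(=O)O[C@@H]2C/C=C(\C)CCCC(C)(C)[C@@H](O)/C=C\2C)ccc1O` has not yet been measured. It differs from compound 2 in one place: methoxy in place of hydrogen on an aromatic carbon. Among the compounds with values here, no step between two measured compounds matches this change, so its size cannot be read from the data. Compound 1 stands at 41500 nM. Compound 2 sits at a limit of the measurement. On this footing the step from compound 2 to compound 3 in this assay is expected to be small, in either direction or none beyond the scatter. The expected step is an at least 1.1-fold lower number from compound 2 to compound 3 (0.04 log units; that floor lies within the scatter). Compound 3 is estimated at 45000 nM in this assay, within a range from 20000 nM to 100000 nM.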

Compound 3, half-maximal inhibitory concentration: > 50000 nM
Compound 3: a limit, no number (the forecaster's own chance of this, stated with the estimate: 50%); at least 1.1-fold (0.04 log units) between middle value and limit.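

Compound 3 adds methoxy to the aromatic ring of compound 2, turning 4-hydroxyphenyl into 4-hydroxy-3-methoxyphenyl, yet in this assay compound 3 gives > 50000 nM, which is a limit of the measurement and not a number. The size of the methoxy step therefore cannot be read, and the same holds for any change at this position on the ring, since both compounds now rest at the same edge of the assay: the limit of > 50000 nM in this assay, at which 2 of the 3 values shown sit.

The one readable result concerns a different place, hydrogen in place of acetyl on an oxygen on a saturated carbon, which gives an at least 1.2-fold higher number from compound 1 to compound 3 (0.08 log units; that floor lies within the scatter), so the data do not yet separate this change from ordinary assay scatter.

Whether methoxy matters at all could only be seen in a pair that keeps the acetyl, with hydrogen or methoxy on the aromatic carbon, and only compound 1 of such a pair is shown. From the compounds shown here alone, what an ethoxy group or an amine at this place on the ring would give also stays open.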